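Shortening an Alkyl Chain: From Octyl Toward Hexyl

The compounds below may be only part of what the source reports. "The series", "measured", "known", "first", "only" and "open" are said of these compounds alone.

Among the measured compounds shown here, compound 2 `CCCCCCCCc1ccc(S(=O)(=O)Nc2cccc(-c3csc(NC(C)=O)n3)c2)cc1` gives 34.8% in a functional assay on A-375 cells (Homo sapiens) for antiproliferative activity, read by trypan blue exclusion, with a stated time of 48 h, tested at 1 uM (on this read-out lower numbers stand for a stronger effect and higher numbers for a weaker effect at the one concentration tested), the lowest of the two numbers measured so far; the nearest is compound 1 `C#Cc1ccc(S(=O)(=O)Nc2cccc(-c3csc(NC(C)=O)n3)c2)cc1` with 59.2%. For the measured compounds named here, the one measured step, a number 24.4 percentage points lower from compound 1 to compound 2 (beyond the scatter), shows that a longer substituent went with a stronger effect beyond the scatter. Compound 3 `CCCCCCc1ccc(S(=O)(=O)Nc2cccc(-c3csc(NC(C)=O)n3)c2)cc1` carries the change (hydrogen in place of ethyl on a saturated chain carbon, six bonds along the chain from an aromatic carbon). Going by the values given here, because the only measured step of a number 24.4 percentage points lower from compound 1 to compound 2 (beyond the scatter) concerns a larger change of the same kind, a partial reversal is expected: a modest move upward, a number 7.2 percentage points higher from compound 2 to compound 3 (within the scatter), is estimated. Compound 3 is therefore expected to give about 42%, within 30% to 58%.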

Compound 3, a percentage reported as activity, at one concentration (the size of the read-out at that concentration, not a potency): 49.9%
Beside the measured number, compound 3's estimate is 7.9 percentage points below it, and the stated range covers the measured number.
By their numbers in this assay, from the lowest: compound 2; then compounds 3 and 1 (each within the scatter of the next).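

In this assay the loss of ethyl from the chain of compound 2 gives a number 15.1 percentage points higher from compound 2 to compound 3 (beyond the scatter) and shows that the read-out still responds to chain length this far from the aromatic carbon. Hexyl in place of ethynyl gives a number 9.3 percentage points lower from compound 1 to compound 3 (within the scatter) and so cannot be told apart from the short group, which leaves the stronger effect with octyl alone among these chains. Nothing available explains this dependence on chain length.

Still open, going by these compounds, is whether a longer chain such as decyl would lower the number further, or whether heptyl would sit nearer to octyl or to hexyl. Equally open, on these data alone, is how an amine at the end of the chain would read.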